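Replacing the Sulfur-Bearing Ring with an Amino-Oxadiazole

The compounds below may be only part of what the source reports. "The series", "measured", "known", "first", "only" and "open" are said of these compounds alone.

Measured so far:
compound 1, `CSc1nnc(Cc2ccc(Cl)cc2Oc2ccccc2Cl)[nH]1`: 132%
compound 2, `CCCSc1nnc(Cc2ccc(Cl)cc2Oc2ccccc2Cl)[nH]1`: 125%

In a functional assay on the whole organism (strain NMRI) with Mus musculus as the target, with a stated time of 60 min, at a dose of 10 mg/kg by the intraperitoneal route (a lower number here means a weaker effect, a higher number a stronger effect of the compound at the dose given), compound 1 gives 132%. Of the two numbers in hand, that of compound 1 stands highest, yet the step of a number 7 percentage points lower from compound 1 to compound 2 (within the scatter) lies within the scatter, so on this read-out the two compounds cannot be told apart.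

Compound 3, `Nc1nnc(Cc2ccc(Cl)cc2Oc2ccccc2Cl)o1`, has not yet been measured. It differs from compound 1 in that (a group of 6 heavy atoms (2 carbon, 3 nitrogen, 1 oxygen; one five-membered aromatic ring with 3 hetero atoms) in place of a group of 7 heavy atoms (3 carbon, 3 nitrogen, 1 sulfur; one five-membered aromatic ring with 3 hetero atoms), on a saturated chain carbon bound to an aromatic carbon). Within the data shown here, the only measured step concerns an ethyl in place of hydrogen on a saturated chain carbon bound to a sulfur, and that sulfur belongs to the group that leaves in compound 3; the step of a number 7 percentage points lower from compound 1 to compound 2 (within the scatter) therefore says little about the present change. Among the measured compounds shown here, no measured pair shows one five-membered aromatic ring exchanged for another. The expected step of a number 22 percentage points lower from compound 1 to compound 3 (beyond the scatter) is thus uncertain in both size and direction, and a wide range is called for. For compound 3 the estimate in this assay is 110%, expected to fall between 60% and 160%.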

Compound 3, a percentage reported as activity, at one dose (the size of the read-out at that dose, not a potency): 132%
For compound 3 the middle estimate is 22 percentage points below the measured one; the range from low to high includes it.
By their numbers in this assay, from the lowest: compounds 2, 1 and 3 (each within the scatter of the next).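

Replacing the sulfur-bearing ring of compound 1 with the 5-amino-1,3,4-oxadiazol-2-yl group, on a saturated chain carbon bound to an aromatic carbon, gives in this assay no change at the digits printed from compound 1 to compound 3 (within the scatter). The earlier pair varied only the chain on the sulfur, whereas compound 3 has neither that sulfur nor its chain and keeps the amino group in their stead, so at this one dose the read-out does not depend on the sulfur being present. The exchange touches the whole ring, swapping a ring nitrogen and the sulfur-linked chain at once, and no measurement here explains why the read-out holds up under so large a change.

Still open is how much freedom this position really has: the compounds shown have only five-membered aromatic rings here, so they cannot say whether a carboxylic acid or a simple amine in place of the ring would keep the effect, or whether a hydroxyl group could stand in for the amino group of compound 3. A read-out at a single dose also leaves open whether compound 1 and compound 3 would still match at lower doses.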